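This account rests on a few compounds, and the source may have more. Where it says the series, first, only, none or still open, it means among the compounds named here.

Three compounds sharing a common core have been examined in an ADME assay on HaCaT cells (Homo sapiens) for cytotoxicity, read by MTT assay, with a stated time of 72 h; on this read-out lower numbers stand for stronger inhibition and higher numbers for weaker inhibition. Compound 1 `Cc1cc(S(=O)(=O)/N=C(\N)n2nccc2-c2ccccc2)c(SCc2cccc(Cl)c2)cc1Cl` gives 10000 nM in this assay. Compound 2 `Cc1cc(S(=O)(=O)/N=C(\N)n2nccc2-c2ccccc2)c(SCc2ccccc2)cc1Cl`, which carries a hydrogen in place of a chloro on an aromatic carbon, gives 18000 nM in this assay; the step is a 1.8-fold higher number from compound 1 to compound 2 (0.26 log units; within the scatter). Compound 3 `Cc1cc(S(=O)(=O)/N=C(\N)n2nccc2-c2ccccc2)c(SCc2ccc(C(F)(F)F)cc2)cc1Cl` gives 19000 nM in this assay. On the numbers shown, compound 3 stands highest of the three, yet the steps of a 1.9-fold higher number from compound 1 to compound 3 (0.28 log units; within the scatter) and a 1.1-fold higher number from compound 2 to compound 3 (0.02 log units; within the scatter) both fall within the scatter, so the three compounds cannot be separated from one another.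

Compound 4 `Cc1cc(S(=O)(=O)/N=C(\N)n2nccc2-c2ccccc2)c(SCc2cccc3ccccc23)cc1Cl` has not yet been measured. It differs from compound 3 by naphthalen-1-yl in place of 4-(trifluoromethyl)phenyl on a saturated chain carbon bound to a sulfur. The step bearing most directly on this change is the one made at the same place, a 1.9-fold higher number from compound 1 to compound 3 (0.28 log units; within the scatter), where one group in place of another on the saturated chain carbon bound to a sulfur moved the number only within the scatter; the step of a 1.1-fold higher number from compound 2 to compound 3 (0.02 log units; within the scatter), a change on an aromatic carbon, was likewise within the scatter. Nothing here suggests that a change at this place carries a step beyond the scatter, so compound 4 is expected to give a number near those already seen, with an expected step of a 1.3-fold lower number from compound 3 to compound 4 (0.10 log units; within the scatter). The estimate for compound 4 in this assay is 15000 nM, with a range from 6000 nM to 40000 nM.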

Compound 4, half-maximal inhibitory concentration: 11000 nM
Estimate against measurement, compound 4: 1.4-fold (0.13 log units) above; the measured number falls inside the stated range.
By their numbers in this assay, from the lowest: compounds 1, 4, 2 and 3 (each within the scatter of the next).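

In this assay, the group on the saturated chain carbon bound to a sulfur now extends to naphthalen-1-yl, with 2 six-membered aromatic rings of carbon only, and this leaves compound 4 within the scatter of all three earlier compounds (a 1.7-fold lower number from compound 3 to compound 4 (0.24 log units; within the scatter); a 1.6-fold lower number from compound 2 to compound 4 (0.21 log units; within the scatter); a 1.1-fold higher number from compound 1 to compound 4 (0.04 log units; within the scatter)). The earlier compounds had shown this only for groups with one such ring, so the result widens the set of groups at this place that cannot be separated, now including one without chloro or trifluoromethyl on a ring larger than phenyl. No measurement offered here accounts for how little the number moves.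

The compounds shown carry only carbon-ring groups with no hydrogen-bond donors or acceptors at this place, so they leave open whether an amine or a carboxylic acid on the ring would carry a step beyond the scatter. They also leave open what naphthalen-2-yl, or a longer chain between the sulfur and the ring, would give.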